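The compounds below may be only part of what the source reports. "The series", "measured", "known", "first", "only" and "open" are said of these compounds alone.

Measured so far in a functional assay on MCF7 cells (Homo sapiens) for cytotoxicity, read by MTT assay, with a stated time of 72 h; on this read-out lower numbers stand for stronger inhibition of growth and higher numbers for weaker inhibition of growth:
Compound 1 `C[Se]c1nc(N)c2ccccc2n1`: compound 1 gives > 100000 nM, a limit of the assay.
Compound 2 `[SeH]c1nc([SeH])c2ccccc2n1`: compound 2 gives 22900 nM.
Compound 3 `Nc1nc([SeH])nc2ncccc12`: compound 3 gives > 100000 nM, a limit of the assay.

For the measured compounds named here, compound 2 thus stands alone with the only real number in this assay; the other two results sit at the limit of > 100000 nM in this assay, at which 2 of the 3 values shown sit. Compound 4 `Nc1nc([SeH])nc2ccccc12` awaits testing. It differs from compound 2 by one nitrogen atom in place of one selenium atom, on an aromatic carbon. Going by the values given here, no step between measured compounds is available here. Compound 3 shares the amino group and the selenol of compound 4, yet compound 3 gives only > 100000 nM, a limit. Compound 1, also amino-bearing, gives > 100000 nM, a limit. The author therefore expects the step from compound 2 to compound 4 to weaken growth inhibition beyond the scatter, estimated at a 4.4-fold higher number from compound 2 to compound 4 (0.64 log units; beyond the scatter). Compound 4 is estimated at 100000 nM, within 20000 nM to 300000 nM.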

Compound 4, concentration for total growth inhibition: > 100000 nM
Compound 4 gave a limit, no number; the forecaster's own chance of this, stated with the estimate: 60%; the middle value sits exactly at the limit.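

Amino in place of the selenium on this aromatic carbon gives an at least 4.3-fold higher number from compound 2 to compound 4 (0.64 log units; beyond the scatter) in this assay, the first readable step among these compounds. As far as these compounds go, compound 4 stands at a limit, so the full size of this step stays unknown, and the step from compound 1 to compound 4 cannot be read. Every amino-bearing compound shown now sits at the same ceiling, and only compound 2 does not: the limit of > 100000 nM in this assay, at which 3 of the 4 values shown sit.

From the compounds shown here alone, whether a thiol or a methylamino group on this carbon would keep the growth inhibition of compound 2 remains open.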